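Swapping thiophenyl for pyridinyl on a shared pyridine core

The source may report more compounds than this note shows. Statements on the series, on what has been measured and on what is new or still open speak of the compounds shown alone.

Measured compounds:
- compound 1 `Oc1cccc(-c2cc(-c3ccc(Cl)cc3)nc(-c3cccs3)c2)c1`: 11600 nM
- compound 2 `Oc1ccc(-c2cc(-c3ccc(Cl)cc3)nc(-c3cccs3)c2)cc1`: 7660 nM
- compound 3 `Oc1ccc(-c2cc(-c3ccncc3)nc(-c3ccccc3Cl)c2)cc1`: "not determined" (no result reported)

In a functional assay on DU-145 cells (Homo sapiens) for cytotoxicity, read by CCK-8 assay and cell counting, with a stated time of 2 days (on this read-out higher numbers stand for weaker inhibition and lower numbers for stronger inhibition), compound 1 gives 11600 nM, the highest of the two numbers available. Its nearest neighbour is compound 2, which in this assay gives 7660 nM; the step of a 1.5-fold lower number from compound 1 to compound 2 (0.18 log units; within the scatter) exchanges a 3-hydroxyphenyl for a 4-hydroxyphenyl on an aromatic carbon and stays within the scatter. Compound 3 carries a pyridin-4-yl and a 2-chlorophenyl on the same core, but in this assay compound 3 gives "not determined" (no result reported).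

Compound 4 `Oc1cccc(-c2cc(-c3ccc(Cl)cc3)nc(-c3ccccn3)c2)c1` has not yet been measured. It differs from compound 1 in one place: pyridin-2-yl in place of thiophen-2-yl on an aromatic carbon. For the measured compounds named here, none of the measured steps touches this position; the only step with a number concerns the hydroxyphenyl group, and it lies within the scatter. There is therefore no basis for expecting a change beyond the scatter in this assay for this exchange, in either direction.

Compound 4 is accordingly expected to come out close to compound 1, at an estimated 11600 nM with a range of 4000 nM to 33000 nM, which means an expected step of no change at the digits printed from compound 1 to compound 4 (within the scatter).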

Compound 4, half-maximal inhibitory concentration: 8090 nM
Estimate against measurement, compound 4: 1.4-fold (0.16 log units) above; low and high end bracket the measured number.
By their numbers in this assay, from the lowest: compounds 2, 4 and 1 (each within the scatter of the next).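

In this assay the position on an aromatic carbon next to the ring nitrogen now has its first measured step: pyridin-2-yl in place of thiophen-2-yl gives a 1.4-fold lower number from compound 1 to compound 4 (0.16 log units; within the scatter) and so stays within the scatter. The earlier compounds shown here gave a number only for moving the hydroxyl group on the hydroxyphenyl ring, whereas this result shows that a five-membered aromatic ring with sulfur and a six-membered aromatic ring with nitrogen can be exchanged here without a step beyond the scatter. Nothing measured on these compounds speaks to why the two rings read alike, and the numbers alone offer no explanation.

The compounds shown leave open whether a group of another kind at this place, such as a morpholine ring, a dimethylamino group or a carboxylic acid, would also stay within the scatter of compound 1 or would move the number beyond it. They also leave open whether the same exchange of thiophen-2-yl for pyridin-2-yl would read alike when the core carries the 4-hydroxyphenyl group of compound 2.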